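The source may report more compounds than this note shows. Statements on the series, on what has been measured and on what is new or still open speak of the compounds shown alone.

Within the data shown here, in a functional assay on HeLa cells (Homo sapiens) for inhibition, read by MTT assay, with a stated time of 72 h (on this read-out higher numbers stand for weaker inhibition and lower numbers for stronger inhibition), compound 1 (`CC(C)c1ccc(C(=O)/C=C/C(=O)O)cc1`) gives 4900 nM and compound 2 (`CC(C)c1ccc(C(=O)/C=C/C(=O)O)c(C(C)C)c1`) gives 4060 nM, so compound 2 stands within the scatter of its sole neighbour. Compound 3 (`CC(C)c1cc(C(C)C)c(C(=O)/C=C/C(=O)O)c(C(C)C)c1`) differs from compound 2 by isopropyl in place of hydrogen on an aromatic carbon, ortho to a (2-carboxyethenyl)carbonyl group. Among the measured compounds shown here, the one measured step of this kind is a 1.2-fold lower number from compound 1 to compound 2 (0.08 log units; within the scatter), which lies within the scatter, so no step beyond the scatter is expected in this assay. The estimated step is a 1.2-fold lower number from compound 2 to compound 3 (0.06 log units; within the scatter). Compound 3 is expected at 3500 nM, within an estimated range of 1300 nM to 9000 nM.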

Compound 3, half-maximal inhibitory concentration: 6100 nM
Compound 3: middle estimate off by 1.7-fold (0.24 log units), on the low side; the range from low to high includes it.
By their numbers in this assay, from the lowest: compounds 2, 1 and 3 (each within the scatter of the next).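

In this assay the change of hydrogen to isopropyl ortho to a (2-carboxyethenyl)carbonyl group and meta to two isopropyl groups gives a 1.5-fold higher number from compound 2 to compound 3 (0.18 log units; within the scatter) and so stays within the scatter. The three compounds thus show no step beyond the scatter for either listed isopropyl change, and this position accepts isopropyl without a separable shift in the number. Nothing available explains this result.

On these data alone, whether a smaller or heteroatom-bearing group at this position, such as methyl, methoxy or an amine, would move the number beyond the scatter stays open.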